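A few compounds are considered here, and "the series" means these few. Any claim that something is new, unique, unknown or untested is made for them only; others in the source may bear on it.

Two compounds share one core and differ in a single spot. Compound 1 `Cc1ccc(-c2ccc(C(=O)Nc3ccc(Oc4ccnc5[nH]ccc45)cc3)nc2)cc1` was tested in a functional assay on A549 cells (Homo sapiens) for cytotoxicity, read by MTT assay, with a stated time of 72 h (a higher number here means a weaker inhibitor, a lower number a stronger inhibitor), and reached only a limit of that assay, > 10000 nM. In this assay compound 2 `Cc1ccc(-c2ccc(C(=O)Nc3ccc(Oc4ccnc5[nH]ccc45)c(F)c3)nc2)cc1` gives 2300 nM, the only plain number shown among these compounds. From the compounds shown here alone, the change from compound 1 to compound 2 is fluoro in place of hydrogen on an aromatic carbon, and the step is an at least 4.3-fold lower number from compound 1 to compound 2 (0.63 log units; beyond the scatter); since compound 1 sits at the limit of > 10000 nM in this assay, at which 1 of the 2 values shown sits, the true size of that step stays open.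

Compound 3 `O=C(Nc1ccc(Oc2ccnc3[nH]ccc23)c(F)c1)c1ccc(-c2ccc(F)cc2)cn1` has not yet been measured. It differs from compound 2 in fluoro in place of methyl on an aromatic carbon. Among the compounds with values here, no measured step covers an exchange of methyl for fluoro; the one step that was measured concerns another pair of groups at another aromatic carbon, so it offers no direct guide. With one small group replaced by another of the same count, the expectation is a step of a 1.3-fold higher number from compound 2 to compound 3 (0.12 log units; within the scatter), not beyond the scatter. Compound 3 is estimated at 3000 nM, with a range from 1000 nM to 9000 nM.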

Compound 3, half-maximal inhibitory concentration: 6010 nM
Compound 3: the middle estimate sits 2.0-fold (0.30 log units) below what was measured; the range from low to high includes it.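

In this assay, the step of a 2.6-fold higher number from compound 2 to compound 3 (0.42 log units; beyond the scatter) shows that this position responds to the exchange of 4-methylphenyl to 4-fluorophenyl, even though one heavy atom simply replaces another and the counts of hydrogen-bond donors and acceptors stay the same. It also shows that entering fluoro does not push the number in one direction across these compounds: at the earlier aromatic carbon, the exchange of hydrogen for fluoro gave an at least 4.3-fold lower number from compound 1 to compound 2 (0.63 log units; beyond the scatter), whereas here fluoro comes with a higher number, though it replaces methyl rather than hydrogen and sits at a different place. Nothing shown gives a measured property that would account for the difference between methyl and fluoro at this position.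

Still open, from the compounds shown here alone, is how other groups at this position would compare, such as a plain hydrogen, a chloro, a methoxy or an amine, and so whether methyl is especially favourable or fluoro especially unfavourable. Also open, going by these compounds, is whether the earlier gain from fluoro at the other aromatic carbon carries over when 4-fluorophenyl takes the place of 4-methylphenyl.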